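The source may report more compounds than this note shows. Statements on the series, on what has been measured and on what is new or still open speak of the compounds shown alone.

Compounds measured so far in a functional assay on CHO cells for antagonist activity at sphingosine 1-phosphate receptor 2 (Homo sapiens), read by scintillation counting and GTPgammaS binding, with a stated time of 4 h, in the presence of a further agent that is not named here; a higher number here means a weaker inhibitor, a lower number a stronger inhibitor:
compound 1, `Cc1cc(NNC(=O)Nc2cc(Cl)nc(Cl)c2)ncc1C#N`, 7 nM
compound 2, `Cc1cc(NNC(=O)Nc2cc(Cl)nc(Cl)c2)ncc1-c1cnn(C)c1`, 3.4 nM

Among the measured compounds shown here, compound 2 holds the lowest of the two numbers in this assay; its only neighbour is compound 1, separated by the step of a 2.1-fold lower number from compound 1 to compound 2 (0.31 log units; beyond the scatter). Compound 3, `Cc1cc(NNC(=O)Nc2cc(Cl)nc(Cl)c2)ncc1-c1ccn(C)n1`, differs from compound 2 by 1-methyl-1H-pyrazol-3-yl in place of 1-methyl-1H-pyrazol-4-yl on an aromatic carbon. For the measured compounds named here, no measured step moves the attachment point of this ring; the single available step, a 2.1-fold lower number from compound 1 to compound 2 (0.31 log units; beyond the scatter), concerns a different exchange and was modest. Compound 3 is therefore expected to stay close to compound 2, with a step of about a 1.3-fold higher number from compound 2 to compound 3 (0.12 log units; within the scatter). The estimate for compound 3 is 4.5 nM, ranging from 1.5 nM to 14 nM.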

Compound 3, half-maximal inhibitory concentration: 9.3 nM
Compound 3: middle estimate off by 2.1-fold (0.32 log units), on the low side; measured number inside the range.
By their numbers in this assay, from the lowest: compound 2; then compounds 1 and 3 (each within the scatter of the next).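

In this assay, exchanging 1-methyl-1H-pyrazol-4-yl for 1-methyl-1H-pyrazol-3-yl, with the same atoms joined differently, gives a step beyond the scatter (a 2.7-fold higher number from compound 2 to compound 3 (0.44 log units; beyond the scatter)), so the number at this position depends on how the ring is attached and not only on which atoms it holds. Replacing the cyano group with 1-methyl-1H-pyrazol-3-yl instead gives a step within the scatter (a 1.3-fold higher number from compound 1 to compound 3 (0.12 log units; within the scatter)), so the step seen with the 4-yl group does not carry over to this attachment. Nothing available explains this difference. The compounds shown leave open how a pyrazole without its methyl group, an amine or a carboxylic acid would fare at this position.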